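Notes on the step from compound 3 to compound 4

The source may hold more compounds than are shown below. What is called first, only, known or untested is meant among the compounds shown, and "the series" means these compounds.

Values in a functional assay on MCF7 cells (Homo sapiens) for antiproliferative activity, read by MTT assay, with a stated time of 48 h; a higher number here means a weaker inhibitor, a lower number a stronger inhibitor:
- Compound 1 `COc1ccc(-n2cc(COc3ccc(/C=C/C(C)=O)cc3OC)nn2)cc1`: 33700 nM
- Compound 2 `COc1cc(/C=C/C(C)=O)ccc1OCc1cn(-c2ccc(C)cc2)nn1`: > 100000 nM, a limit of the assay
- Compound 3 `COc1cc(/C=C/C(C)=O)ccc1OCc1cn(-c2ccccc2Cl)nn1`: 2190 nM

Compound 3 has the lowest number of the three, and the nearest measured number belongs to compound 1 at 33700 nM.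

Compound 4 `COc1cc(/C=C/C(C)=O)ccc1OCc1cn(-c2cc(F)cc(Br)c2)nn1` carries 3-bromo-5-fluorophenyl in place of 2-chlorophenyl on an aromatic nitrogen of a five-membered aromatic ring with 3 nitrogen (3-bromo-5-fluorophenyl in place of 2-chlorophenyl on an aromatic nitrogen).

All three measured steps change the group at this same place. They are an at least 2.9-fold higher number from compound 1 to compound 2 (0.47 log units; beyond the scatter), a 15-fold lower number from compound 1 to compound 3 (1.19 log units; beyond the scatter) and an at least 45-fold lower number from compound 2 to compound 3 (1.65 log units; beyond the scatter). Each lies beyond the scatter, and the last two are large. None of them brings in bromine or fluorine, so they show how far this place can move the number in this assay but not what the new group will do. A step beyond the scatter is therefore expected. Among the measured compounds shown here, with compound 3 at 2190 nM, the lowest number so far, a higher number is the likelier direction, probably smaller than the large steps, though a lower number cannot be excluded.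

For compound 4 the estimated value is 7000 nM, with an expected range of 1200 nM to 40000 nM. The estimated change is a 3.2-fold higher number from compound 3 to compound 4 (0.50 log units; beyond the scatter).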

Compound 4, half-maximal inhibitory concentration: 65500 nM
Beside the measured number, compound 4's estimate is 9.4-fold (0.97 log units) below it; the whole stated range lies below it.
By their numbers in this assay, from the lowest: compound 3; then compounds 1 and 4 (each within the scatter of the next). At a limit, above all of these: compound 2.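

In this assay, 3-bromo-5-fluorophenyl in place of 2-chlorophenyl gives a 30-fold higher number from compound 3 to compound 4 (1.48 log units; beyond the scatter) and thus shows that a halogen on the phenyl ring does not by itself carry the low number of compound 3, while the same group in place of 4-methoxyphenyl gives a 1.9-fold higher number from compound 1 to compound 4 (0.29 log units; within the scatter) and leaves those two compounds without an order. Among the compounds shown here, in place of 4-methylphenyl it gives an at least 1.5-fold lower number from compound 2 to compound 4 (0.18 log units; that floor lies within the scatter) and so adds no separation from compound 2 either, which leaves compound 3 as the only compound here whose steps to all the others lie beyond the scatter. The value of compound 2 is a limit of the assay, not a number: the limit of > 100000 nM in this assay, at which 1 of the 4 values shown sits.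

From the compounds shown here alone, whether the low number of compound 3 goes with chlorine itself or with the place it occupies stays open, and 3-chlorophenyl or 2-bromophenyl on the same ring nitrogen would separate the two. Also open, going by these compounds, is how this assay responds to a phenyl ring bearing an amine or a carboxylic acid, or to an alkyl chain in place of the ring on that nitrogen.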